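From 4-fluorophenyl to phenoxy: two weak inhibitors and a third

The source may report more compounds than this note shows. Statements on the series, on what has been measured and on what is new or still open speak of the compounds shown alone.

Of the compounds shown here, two sharing one core have been measured in an assay on isolated protein for inhibition of 2-Hydroxyacid oxidase 2 (Homo sapiens), tested at 1 uM; on this read-out higher numbers stand for a stronger effect at the one concentration tested and lower numbers for a weaker effect. Compound 1, `Cc1n[nH]c(C(=O)O)c1Cc1ccc2ccccc2n1`, gives 2% in this assay. Compound 2, `Cc1n[nH]c(C(=O)O)c1Cc1ccccc1-c1ccc(F)cc1`, gives 11% in this assay. Compound 2 thus stands highest of the two numbers shown, but its only neighbour, compound 1, lies lower by an amount within the usual scatter, so the two cannot be told apart. Compound 3, `Cc1n[nH]c(C(=O)O)c1Cc1ccccc1Oc1ccccc1`, has not yet been measured. It differs from compound 2 in one place: phenoxy in place of 4-fluorophenyl on an aromatic carbon. Going by the values given here, no step between measured compounds that differ in one place is available, and the expectation for compound 3 therefore rests only on the low readings of compound 1 and compound 2 in this assay. The expected step is a number 3 percentage points lower from compound 2 to compound 3 (within the scatter), none beyond the scatter. Compound 3 is estimated at 8%, with a range from -5% to 25%.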

Compound 3, a percentage reported as inhibition, at one concentration (the size of the read-out at that concentration, not a potency): 9%
Estimate against measurement, compound 3: 1 percentage points below; measured number inside the range.
By their numbers in this assay, from the lowest: compounds 1, 3 and 2 (each within the scatter of the next).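

In this assay, going by these compounds alone, phenoxy in place of 4-fluorophenyl on an aromatic carbon, ortho to a large group, gives the first step that can be read at a single place: a number 2 percentage points lower from compound 2 to compound 3 (within the scatter). Bringing in the hydrogen-bond acceptor that phenoxy carries and 4-fluorophenyl lacks therefore leaves the reading unchanged beyond the scatter, and this exchange of one aromatic substituent for another does not lift the series out of its low readings. Nothing at hand bears on the reason for this result.

Going by these compounds, it remains open whether an amine, a morpholine or a methoxy group at this place would move the reading beyond the scatter. On these data alone, it is also open how these compounds would compare as potencies, since a reading at one concentration does not give one.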